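Removing the chlorine from a hydrazone: what to expect

The source may report more compounds than this note shows. Statements on the series, on what has been measured and on what is new or still open speak of the compounds shown alone.

Two compounds have been run in a functional assay on NCI-H23 cells (Homo sapiens) for antiproliferative activity, read by sulforhodamine B assay, with a stated time of 48 h; on this read-out higher numbers stand for weaker inhibition of growth and lower numbers for stronger inhibition of growth. Compound 1, `COc1ccc(OC)c(/C=C/c2nnc(Nc3ccc(Cl)cc3)o2)c1`, reaches only the limit of the assay in this assay, giving > 100000 nM, which is a limit and not a number. Among the measured compounds shown here, compound 2, `COc1ccc(OC)c(/C=C/C(=O)N/N=C/c2ccc(Cl)cc2)c1`, is the only compound with a real number, and in this assay compound 2 gives 2460 nM. So compound 2 stands alone as the single measured value, while the other result sits at the limit of > 100000 nM in this assay, at which 1 of the 2 values shown sits. For the measured compounds named here, no step between two measured compounds is available, so the size of the change from compound 2 to compound 3 must be guessed rather than read off.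

Compound 3, `COc1ccc(OC)c(/C=C/C(=O)N/N=C/c2ccccc2)c1`, differs from compound 2 by hydrogen in place of chloro on an aromatic carbon. Going by the values given here, the only change is the loss of a single chlorine, with a hydrogen in its place. Such a small change in a tail group, with the rest of the molecule untouched, is expected to shift growth inhibition only modestly, if at all, and most likely toward weaker inhibition, with the step staying within the scatter. Compound 3 is therefore expected at a 1.6-fold higher number from compound 2 to compound 3 (0.21 log units; within the scatter), which gives an estimate for compound 3 of 4000 nM, with a plausible range from 1500 nM to 12000 nM.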

Compound 3, concentration for total growth inhibition: 87000 nM
Compound 3: the middle estimate sits 22-fold (1.34 log units) below what was measured; measured number above the stated range.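

In this assay, replacing chloro with hydrogen on the aromatic carbon gives a 35-fold higher number from compound 2 to compound 3 (1.55 log units; beyond the scatter), so at this place, para to a large group, the 4-chlorophenyl to phenyl change is far from a minor edit to the tail. Among the compounds shown here, only one heavy atom leaves, with no ring, no net charge and no hydrogen-bond donor or acceptor counted in the change, and yet that single chlorine separates a micromolar-range result from a much weaker one, a contrast the earlier compounds could not show because no step between measured compounds was available. The values shown give no measured property that would explain why this one atom matters so much.

As far as these compounds go, it remains open whether the gain belongs to chlorine itself or whether another group at the same place, such as a bromine, a methyl group, a methoxy group or an amine, would hold growth inhibition as well. The compounds shown also leave open whether this large step would recur with a different group at the other end of the molecule, since it rests on a single pair.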